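Chloro for phenyl at the aryl ring, amide kept

The compounds below may be only part of what the source reports. "The series", "measured", "known", "first", "only" and "open" are said of these compounds alone.

Of the compounds shown here, two have been measured in a functional assay on SH-SY5Y cells (Homo sapiens) for cytotoxicity, tested at 300 nM; on this read-out higher numbers stand for a weaker effect at the one concentration tested and lower numbers for a stronger effect. Compound 1 `O=C(CCCCCCn1cc(-c2cccnc2)nn1)Nc1ccccc1-c1ccccc1` gives 88.2% in this assay, the highest of the two numbers; compound 2 `O=C(CCCCCCn1cc(-c2cccnc2)nn1)Oc1ccccc1-c1ccccc1` gives 74.7%, a number that lies beyond the usual scatter from that of compound 1. Within the data shown here, no step between measured compounds that differ in a single place is available, so the change considered here has no measured precedent.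

Compound 3 `O=C(CCCCCCn1cc(-c2cccnc2)nn1)Nc1ccccc1Cl` differs from compound 1 by chloro in place of phenyl on an aromatic carbon. The rest of the molecule is left as it stands in compound 1. Among the measured compounds shown here, with both measured values on the weak side of this assay and no single-place step to lean on, the step is expected to be small, in no set direction, and within the scatter: a number 3.2 percentage points lower from compound 1 to compound 3 (within the scatter). Compound 3 is therefore expected to give about 85%, with a range from 70% to 100%.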

Compound 3, a percentage reported as activity, at one concentration (the size of the read-out at that concentration, not a potency): 79.5%
Compound 3: middle estimate off by 5.5 percentage points, on the high side, within the range that was stated.
By their numbers in this assay, from the lowest: compounds 2, 3 and 1 (each within the scatter of the next, the first and the last beyond it).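

In this assay, the series now has its first single-place step, at an aromatic carbon ortho to a large group: chloro in place of phenyl gives a number 8.7 percentage points lower from compound 1 to compound 3 (within the scatter). This position therefore accepts the exchange of a six-membered aromatic ring of carbon only, with its six heavy atoms, for a single chlorine without a change in the read-out beyond the scatter at the one concentration tested. No available evidence bears on what lies behind this step.

On these data alone, it remains open how an amine or a carboxylic acid on this aromatic carbon would read in this assay. As far as these compounds go, it is also open whether chloro in place of phenyl would give a comparable step in the ester of compound 2, or with a longer chain in the shared core.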